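Working notes: from compound 3 to compound 4

A few compounds are considered here, and "the series" means these few. Any claim that something is new, unique, unknown or untested is made for them only; others in the source may bear on it.

Values measured in an ADME assay on cells (Peritoneal macrophage, Mus musculus, strain Balb/c) for cytotoxicity, read by resazurin assay, with a stated time of 72 h; on this read-out higher numbers stand for lower toxicity in this test and lower numbers for higher toxicity in this test
- compound 1 `CCC1(CC)CC(S(=O)(=O)c2ccc(F)cc2)=C(c2ccc(/C(N)=N/O)cc2)O1` gives 91400 nM
- compound 2 `CC1(Cc2cccc(C(F)(F)F)c2)CC(S(=O)(=O)c2ccc(F)cc2)=C(c2ccc(/C(N)=N/O)cc2)O1` gives 49800 nM
- compound 3 `CC1(Cc2ccc([N+](=O)[O-])cc2)CC(S(=O)(=O)c2ccc(F)cc2)=C(c2ccc(/C(N)=N/O)cc2)O1` gives 97400 nM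

Compound 3 at 97400 nM lies within the scatter of both compound 1 and compound 2. Compound 4 `CC1(Cc2cccc(CO)c2)CC(S(=O)(=O)c2ccc(F)cc2)=C(c2ccc(/C(N)=N/O)cc2)O1` is still unmeasured. Its difference from compound 3 is 3-(hydroxymethyl)phenyl in place of 4-nitrophenyl on a saturated chain carbon bound to a saturated ring carbon, in words 3-(hydroxymethyl)phenyl in place of 4-nitrophenyl on a saturated chain carbon bound to a saturated ring carbon. Within the data shown here, no measured compound carries the incoming group. Among the measured compounds shown here, the only measured step at this place is a 2.0-fold higher number from compound 2 to compound 3 (0.29 log units; within the scatter) and from it no step beyond the scatter is expected in this assay, in either direction. The expected step is a 1.2-fold lower number from compound 3 to compound 4 (0.09 log units; within the scatter), within the scatter. For compound 4 the estimated value is 80000 nM, with an expected range of 40000 nM to 160000 nM.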

Compound 4, half-maximal cytotoxic concentration: > 100000 nM
Compound 4 was reported as a limit; the forecaster's own chance of this, stated with the estimate: 20%; at least 1.2-fold (0.09 log units) between middle value and limit.
By their numbers in this assay, from the lowest: compounds 2, 1 and 3 (each within the scatter of the next). At a limit, above all of these: compound 4.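

In this assay compound 4 gives > 100000 nM, which is a limit of the assay and not a number. 3-(Hydroxymethyl)phenyl, which brings a hydrogen-bond donor to this place, shows no drop in the number, with an at least 1.0-fold higher number from compound 3 to compound 4 (0.01 log units; that floor lies within the scatter) and an at least 2.0-fold higher number from compound 2 to compound 4 (0.30 log units; that floor lies within the scatter). Among these compounds, neither floor separates compound 4 from the earlier compounds, and the true size of both steps stays hidden: the limit of > 100000 nM in this assay, at which 1 of the 4 values shown sits.

Still open, going by these compounds, is how far compound 4 lies past the limit, and whether an amine or a carboxylic acid in place of hydroxymethyl on an aromatic carbon also reaches that limit.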